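Second chloro on the core of compound 3

A few compounds are considered here, and "the series" means these few. Any claim that something is new, unique, unknown or untested is made for them only; others in the source may bear on it.

Compound 1 `ClCc1ccccc1Cn1cnc2c(Cl)nc(Cl)nc21`: 30 nM
Compound 2 `ClCc1ccccc1Cn1cnc2c(Cl)ncnc21`: 1280 nM
Compound 3 `ClCc1cccc(Cn2cnc3c(Cl)ncnc32)c1`: 1900 nM

Of the compounds shown here, three have been measured in a functional assay on CCRF-CEM cells (Homo sapiens) for cytotoxicity, read by sulforhodamine B assay, with a stated time of 48 h; on this read-out lower numbers stand for stronger inhibition of growth and higher numbers for weaker inhibition of growth. Compound 1 gives 30 nM, compound 2 gives 1280 nM, and compound 3 gives 1900 nM. Compound 3 thus stands at the highest of the three numbers; its value and that of compound 2 lie within the scatter of each other, whereas the gap to compound 1 is well beyond it.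

Compound 4 `ClCc1cccc(Cn2cnc3c(Cl)nc(Cl)nc32)c1` has not yet been measured in this assay. It differs from compound 3 in one place: chloro in place of hydrogen on an aromatic carbon, on the carbon between two ring nitrogen atoms.

For the measured compounds named here, one measured step bears on this change, in the opposite direction: a 43-fold higher number from compound 1 to compound 2 (1.63 log units; beyond the scatter). Compound 2 and compound 3 carry the same core with the chloromethylbenzyl group attached at different positions, and their values in this assay lie within the scatter of each other, so the step seen on going from compound 1 to compound 2 is taken as the best guide.

A large step in this assay toward a lower number is therefore expected from compound 3 to compound 4, a 42-fold lower number from compound 3 to compound 4 (1.63 log units; beyond the scatter). Compound 4 is estimated at 45 nM, with a range from 15 nM to 150 nM, because of the size of a 43-fold higher number from compound 1 to compound 2 (1.63 log units; beyond the scatter).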

Compound 4, concentration for 50% growth inhibition: 2690 nM
Compound 4: the middle estimate sits 60-fold (1.78 log units) below what was measured, and the stated range ends below it.
By their numbers in this assay, from the lowest: compound 1; then compounds 2, 3 and 4 (each within the scatter of the next, the first and the last beyond it).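

In this assay, chloro in place of hydrogen on the aromatic carbon between two ring nitrogen atoms gives a 1.4-fold higher number from compound 3 to compound 4 (0.15 log units; within the scatter), so on this core the change has no effect that can be told from the scatter. The large step seen earlier therefore does not carry over between the two cores, which differ only in where the chloromethyl group sits on the benzyl ring: the same change on two cores in this assay, a 43-fold higher number (1.63 log units; beyond the scatter) from compound 1 to compound 2 and a 1.4-fold lower number (0.15 log units; within the scatter) from compound 4 to compound 3, 60-fold (1.78 log units) apart, beyond the scatter of two such steps. Of the two compounds that carry this chloro, compound 1 gives 30 nM and compound 4 gives 2690 nM, so the low number belongs to one combination of chloro and chloromethyl placement, not to the chloro alone.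

The compounds shown leave open whether another group on this carbon, such as an amine or a methoxy group, would depend on the chloromethyl placement in the same way. They also leave open whether the low number of compound 1 would survive if the chloromethyl group gave way to a longer chain, such as chloroethyl, or to a hydroxymethyl group.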